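Trading a ring-bearing group for an isopropylsulfonyl

A few compounds are considered here, and "the series" means these few. Any claim that something is new, unique, unknown or untested is made for them only; others in the source may bear on it.

Compound 1 `CCCCOC(=O)N1CCC(Oc2ncnc3c2CCN3c2ccc(S(C)(=O)=O)cc2F)CC1` gives 50.1 nM
Compound 2 `CCSC(=O)N1CCC(Oc2ncnc3c2CCN3c2ccc(S(C)(=O)=O)cc2F)CC1` gives 31.6 nM
Compound 3 `CS(=O)(=O)c1ccc(N2CCc3c(OC4CCN(C(=S)Sc5ccccc5)CC4)ncnc32)c(F)c1` gives 12.6 nM

Three compounds share one core and differ only in the group attached to the amine nitrogen of the six-membered ring. All were tested in a functional assay on CHO-K1 cells for agonist activity at Glucose-dependent insulinotropic receptor (Homo sapiens), read by a luciferase reporter, with a stated time of 5 h; a lower number here means that less compound is needed, a higher number that more compound is needed for the effect. Compound 3 carries the lowest number of the three: the change from compound 1 to compound 3 gave a 4.0-fold lower number from compound 1 to compound 3 (0.60 log units; beyond the scatter), and the change from compound 2 to compound 3 gave a 2.5-fold lower number from compound 2 to compound 3 (0.40 log units; beyond the scatter). Between compound 1 and compound 2 the change was a 1.6-fold lower number from compound 1 to compound 2 (0.20 log units; within the scatter), so these two cannot be told apart.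

Compound 4 `CC(C)S(=O)(=O)N1CCC(Oc2ncnc3c2CCN3c2ccc(S(C)(=O)=O)cc2F)CC1` is the next step from compound 3. The change is a group of 6 heavy atoms (3 carbon, 2 oxygen, 1 sulfur; no ring) in place of a group of 9 heavy atoms (7 carbon, 2 sulfur; one six-membered aromatic ring of carbon only), on an amine nitrogen in a ring. The two steps that bear on it both went the other way, from a smaller group without a ring to the larger ring-bearing group, and both lowered the number modestly. Compound 4 removes that ring-bearing group again and installs an isopropylsulfonyl, a small group with no ring, closer in size to what compounds 1 and 2 carry. A modest rise back toward those two compounds is therefore expected, although an isopropylsulfonyl has not itself been tried here. The expected step is a 2.8-fold higher number from compound 3 to compound 4 (0.44 log units; beyond the scatter). For compound 4 the estimate is 35 nM, with a range from 12 nM to 100 nM.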

Compound 4, half-maximal effective concentration: 1260 nM
Compound 4: the middle estimate sits 36-fold (1.56 log units) below what was measured; measured number outside the range, above it.
By their numbers in this assay, from the lowest: compound 3; then compounds 2 and 1 (each within the scatter of the next); then compound 4.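

Putting isopropylsulfonyl on the amine nitrogen in a ring gives a 100-fold higher number from compound 3 to compound 4 (2.00 log units; beyond the scatter) in this assay and shows that this position tolerates far less variety than the earlier, narrowly spaced numbers suggested. Losing the aromatic ring cannot be the whole story, since compounds 1 and 2 also carry groups with no ring, yet the other two steps are a 40-fold higher number from compound 2 to compound 4 (1.60 log units; beyond the scatter) and a 25-fold higher number from compound 1 to compound 4 (1.40 log units; beyond the scatter), both large. Compound 4 is also the only one of the four with a sulfonyl rather than a carbonyl or thiocarbonyl on this nitrogen, so the large steps coincide with that swap, but no measurement shown here explains why the number rises so far.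

The compounds shown leave open whether the sulfonyl itself or the isopropyl on it matters more, which methylsulfonyl or phenylsulfonyl on the same nitrogen could help separate. They also leave open how much of compound 3's low number comes from its phenyl ring and how much from its thiocarbonyl, a question that phenoxycarbonyl could address.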